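Pyridinyl for Furanyl on Two Hydroxyphenyl Pyridine Cores

The compounds below may be only part of what the source reports. "The series", "measured", "known", "first", "only" and "open" are said of these compounds alone.

Compound 1 `Oc1cccc(-c2cc(-c3ccccc3)cc(-c3ccco3)n2)c1` and compound 3 `Oc1ccc(-c2cc(-c3ccccc3)nc(-c3ccco3)c2)cc1` are built from the same atoms joined differently; the difference between the two cores is not broken down here. In a functional assay on DU-145 cells (Homo sapiens) for cytotoxicity, read by ELISA, with a stated time of 2 days (on this read-out lower numbers stand for stronger inhibition and higher numbers for weaker inhibition), compound 1 gives 14400 nM, and compound 3 gives 8600 nM, a gap within the scatter. Compound 2 `Oc1cccc(-c2cc(-c3ccccc3)cc(-c3ccncc3)n2)c1` carries the change (pyridin-4-yl in place of furan-2-yl on an aromatic carbon), and in this assay compound 2 gives 19200 nM, which is a 1.3-fold higher number from compound 1 to compound 2 (0.12 log units; within the scatter). Compound 4 `Oc1ccc(-c2cc(-c3ccccc3)nc(-c3ccncc3)c2)cc1` carries the same kind of change, (pyridin-4-yl in place of furan-2-yl on an aromatic carbon), though its place is meta to a 4-hydroxyphenyl group rather than meta to a 3-hydroxyphenyl group. Compound 4 is expected to give 11000 nM in this assay because a 1.3-fold higher number from compound 1 to compound 2 (0.12 log units; within the scatter) stayed within the scatter. That estimate means an expected step of a 1.3-fold higher number from compound 3 to compound 4 (0.11 log units; within the scatter), with the range 5000 nM to 25000 nM.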

Compound 4, half-maximal inhibitory concentration: 2200 nM
Estimate against measurement, compound 4: 5.0-fold (0.70 log units) above; measured number outside the range, below it.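

In this assay the change of furan-2-yl to pyridin-4-yl gives a 3.9-fold lower number from compound 3 to compound 4 (0.59 log units; beyond the scatter) on the core of compound 3, so on this core the step is a real one. The same change did not carry over with the same size from one core to the other: the same change on two cores in this assay, a 1.3-fold higher number (0.12 log units; within the scatter) from compound 1 to compound 2 and a 3.9-fold lower number (0.59 log units; beyond the scatter) from compound 3 to compound 4, 5.2-fold (0.72 log units) apart, beyond the scatter of two such steps

That contrast rests on a single pair for each core, so it shows that the outcome differs between these two cores, but not which feature of the cores lies behind it.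

The compounds shown leave open how an amine or a carboxylic acid would fare in place of furan-2-yl on the core of compound 3 in this assay. They also leave open whether this change on further cores would follow the pair ending in compound 2 or the pair ending in compound 4.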